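This account rests on a few compounds, and the source may have more. Where it says the series, first, only, none or still open, it means among the compounds named here.

Compound 1 `CC(C)N(Cc1cccc(OCCCCCC(=O)O)c1)C(=O)c1ccc(-c2cccc(Br)c2)cc1`: > 26000 nM
Compound 2 `CCOC(=O)CCCCCOc1cccc(CN(C(=O)c2ccc(-c3cccnc3)cc2)C(C)C)c1`: > 26000 nM

In an ADME assay on HEK293 cells (Homo sapiens) for cytotoxicity, read by CellTiter-Glo and resazurin assay, with a stated time of 72 h (on this read-out lower numbers stand for an effect already at smaller amounts and higher numbers for an effect only at larger amounts of compound), compound 2 reaches only a limit of the assay, > 26000 nM, and not a number. Compound 1 likewise gives only a limit in this assay, > 26000 nM. Going by the values given here, this places compound 2 at the limit of > 26000 nM in this assay, at which 2 of the 2 values shown sit, so the two measured compounds stand together at the same limit, and no measured step between them exists; of this pair nothing more can be said than that both values are limits.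

The unmeasured compound 3 `CCOC(=O)CCCCCOc1cccc(CN(C(=O)c2ccc(-c3cccc(O)c3)cc2)C(C)C)c1` differs from compound 2 in one place: 3-hydroxyphenyl in place of pyridin-3-yl on an aromatic carbon.

Among the compounds with values here, with no measured step in this assay to lean on, the change from compound 2 to compound 3 is expected to give no step beyond the usual scatter, and a limit rather than a number is the likelier outcome for compound 3. The estimate for compound 3 in this assay is 30000 nM, with a range from 15000 nM to 100000 nM. The expected change that this implies is a step that the limit leaves unreadable from compound 2 to compound 3.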

Compound 3, half-maximal effective concentration: > 26000 nM
Compound 3 ended at the assay's limit; the forecaster's own chance of this, stated with the estimate: 80%; the middle value does not contradict the limit.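

In this assay, going by these compounds alone, compound 3 gives only a limit and not a number, as compound 2 does, so no step from compound 2 to compound 3 can be read: the limit of > 26000 nM in this assay, at which 3 of the 3 values shown sit. The compounds shown leave open where the true values of these compounds lie, and whether 3-hydroxyphenyl in place of pyridin-3-yl changes the value at all in this assay.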